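Swapping the Carbonyl-Side Aryl Group for Plain Phenyl

The source may report more compounds than this note shows. Statements on the series, on what has been measured and on what is new or still open speak of the compounds shown alone.

Compound 1 `COc1ccc(C(=O)/C=C/c2cc(-c3cc(OC)c(OC)c(OC)c3)n3nc(-c4ccccc4)cc3n2)cc1OC`: 17800 nM
Compound 2 `COc1ccc(-c2cc(C(=O)/C=C/c3cc(OC)c(OC)c(OC)c3)nc3cc(-c4ccccc4)nn23)cc1OC`: 15400 nM
Compound 3 `COc1ccc(/C=C/C(=O)c2cc(-c3ccc(OC)c(OC)c3)n3nc(-c4ccccc4)cc3n2)cc1`: 19300 nM

Of the compounds shown here, three sharing the same core have been tested in a functional assay on A549 cells (Homo sapiens) for antiproliferative activity, read by MTT assay, with a stated time of 24 h; a higher number here means a weaker inhibitor, a lower number a stronger inhibitor. Compound 1 gives 17800 nM, compound 2 gives 15400 nM and compound 3 gives 19300 nM. Compound 1 sits second highest of the three numbers, but its gaps to compound 2 and to compound 3 are both within the scatter, so the three cannot be told apart.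

Among the measured compounds shown here, the one measured step, a 1.3-fold higher number from compound 2 to compound 3 (0.10 log units; within the scatter), concerns a change on a double-bonded chain carbon and stays within the scatter.

Compound 4 `COc1cc(-c2cc(/C=C/C(=O)c3ccccc3)nc3cc(-c4ccccc4)nn23)cc(OC)c1OC` differs from compound 1 by phenyl in place of 3,4-dimethoxyphenyl on a carbonyl carbon. For the measured compounds named here, this change sits on the carbonyl carbon, a different place from the one tested in the step from compound 2 to compound 3, so no measured step bears directly on it. Going by the values given here, the only evidence is that trimming methoxy groups elsewhere left the number unchanged. The expected step of a 1.1-fold higher number from compound 1 to compound 4 (0.05 log units; within the scatter) is therefore none beyond the scatter. Compound 4 is estimated at 20000 nM, with a range from 8000 nM to 50000 nM.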

Compound 4, half-maximal inhibitory concentration: 18200 nM
Estimate against measurement, compound 4: 1.1-fold (0.04 log units) above; the measured number falls inside the stated range.
By their numbers in this assay, from the lowest: compounds 2, 1, 4 and 3 (each within the scatter of the next).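

In this assay, the change from 3,4-dimethoxyphenyl to phenyl on the carbonyl carbon gives a 1.0-fold higher number from compound 1 to compound 4 (0.01 log units; within the scatter) and so stays within the scatter. Among the compounds shown here, this is the first measured step at this carbonyl position, as the only earlier step concerned a double-bonded chain carbon, and it shows that the ring here can lose its methoxy groups, leaving plain phenyl, with no measurable shift in the number. For compound 1 and compound 4, then, these methoxy groups make no difference that this measurement can detect, and no information is available on why the number holds steady.

On these data alone, the phenyl on the carbonyl carbon remains open to other groups, such as an amine or a carboxylic acid on that ring, or a short alkyl chain in place of the ring, any of which might or might not move the number beyond the scatter. Each of the four compounds shown lies within the scatter of the next, so they do not yet reveal which change, at this position or elsewhere on the shared core, would shift the number in this assay in either direction.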